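The source may hold more compounds than are shown below. What is called first, only, known or untested is meant among the compounds shown, and "the series" means these compounds.

Among the compounds with values here, compound 1, `COc1ncc(C(=O)NC2(C(=O)N[C@H](C)c3ccc(-n4nc(Cl)c5ccccc54)cc3F)CC2)s1`, is one of two compounds measured in an in vivo ADME assay on the whole organism (strain Mongrel) for pharmacokinetics, with Canis familiaris (Canis lupus familiaris) as the target; on this read-out lower numbers stand for slow clearance and higher numbers for fast clearance. In this assay compound 1 gives 1.7 mL/min/kg, the lower of the two numbers. Compound 2, `C[C@@H](NC(=O)C1(NC(=O)c2cncc(Br)c2)CC1)c1ccc(-n2nc(Cl)c3ccccc32)cc1F`, gives 3.8 mL/min/kg in this assay. Within the data shown here, the only measured step is a 2.2-fold higher number from compound 1 to compound 2 (0.35 log units; beyond the scatter), in which a 5-bromopyridin-3-yl takes the place of the 2-methoxy-1,3-thiazol-5-yl on a carbonyl carbon. Compound 3, `COc1cc(C(=O)NC2(C(=O)N[C@H](C)c3ccc(-n4nc(Cl)c5ccccc54)cc3F)CC2)on1`, has not yet been measured. It differs from compound 1 as follows: 3-methoxy-1,2-oxazol-5-yl in place of 2-methoxy-1,3-thiazol-5-yl on a carbonyl carbon. Among the measured compounds shown here, this change swaps one five-membered aromatic ring with 2 hetero atoms for another at the same carbonyl carbon, so it resembles the one measured step in kind. Because that step was a 2.2-fold higher number from compound 1 to compound 2 (0.35 log units; beyond the scatter), a small rise or no change beyond the scatter is expected, and the expected step is a 1.5-fold higher number from compound 1 to compound 3 (0.17 log units; within the scatter). For compound 3 the estimate in this assay is 2.5 mL/min/kg, with a range from 1.2 mL/min/kg to 5 mL/min/kg.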

Compound 3, clearance: 1.3 mL/min/kg
Compound 3: the middle estimate sits 1.9-fold (0.28 log units) above what was measured, within the range that was stated.
By their numbers in this assay, from the lowest: compounds 3 and 1 (each within the scatter of the next); then compound 2.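

In this assay, the 3-methoxy-1,2-oxazol-5-yl in place of the 2-methoxy-1,3-thiazol-5-yl leaves the two compounds indistinguishable (a 1.3-fold lower number from compound 1 to compound 3 (0.12 log units; within the scatter)), so on this carbonyl carbon one five-membered aromatic ring with 2 hetero atoms can replace the other without a difference that this measurement can resolve. The 5-bromopyridin-3-yl now stands apart from two such rings rather than one, with a second step beyond the scatter (a 2.9-fold lower number from compound 2 to compound 3 (0.47 log units; beyond the scatter)). No measured evidence is available to explain these numbers.

From the compounds shown here alone, all three groups compared at this place are aromatic rings carrying a substituent, so it remains open how a saturated amine such as piperidine or a carboxylic acid would read there. Going by these compounds, it is also open whether the methoxy group itself matters, as a methyl group in its place would show.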